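A few compounds are considered here, and "the series" means these few. Any claim that something is new, unique, unknown or untested is made for them only; others in the source may bear on it.

Working notes on the series. In an ADME assay on BJ cells (Homo sapiens) for cytotoxicity, read by MTT assay, with a stated time of 72 h (on this read-out higher numbers stand for lower toxicity in this test and lower numbers for higher toxicity in this test), compound 1 `OC[C@H]1O[C@@H](n2cc(F)c3c(-c4ccccc4)ncnc32)[C@H](O)[C@@H]1O`, which carries phenyl, gives > 50000 nM, and this value is a limit of the assay. Compound 2 `OC[C@H]1O[C@@H](n2cc(F)c3c(-c4cccs4)ncnc32)[C@H](O)[C@@H]1O`, with thiophen-2-yl, gives 170 nM. Compound 3 `OC[C@H]1O[C@@H](n2cc(F)c3c(-c4ccsc4)ncnc32)[C@H](O)[C@@H]1O`, with thiophen-3-yl, gives 620 nM, the higher of the two actual numbers, and compound 2 is its nearest neighbour.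

The next member is compound 4 `OC[C@H]1O[C@@H](n2cc(F)c3c(-c4cc[nH]c4)ncnc32)[C@H](O)[C@@H]1O`, with 1H-pyrrol-3-yl in place of thiophen-3-yl on an aromatic carbon.

Among the measured compounds shown here, three measured steps bear on this. Two are large: an at least 290-fold lower number from compound 1 to compound 2 (2.46 log units; beyond the scatter) and an at least 80-fold lower number from compound 1 to compound 3 (1.90 log units; beyond the scatter). Both start from a limit, (the limit of > 50000 nM in this assay, at which 1 of the 3 values shown sits), and both replace phenyl, so they do not match the present change, which keeps a five-membered aromatic ring with 1 hetero atom. The closest guide is the modest 3.6-fold higher number from compound 2 to compound 3 (0.56 log units; beyond the scatter), a change between two five-membered rings. For the measured compounds named here, no measured step exchanges the hetero atom itself, so the direction is uncertain. A small move toward a higher number in this assay is expected, probably not clearly beyond the scatter.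

The expected change is a 1.6-fold higher number from compound 3 to compound 4 (0.21 log units; within the scatter). For compound 4 the estimated value is 1000 nM, with an expected range of 150 nM to 8000 nM.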

Compound 4, half-maximal cytotoxic concentration: 2020 nM
Estimate against measurement, compound 4: 2.0-fold (0.31 log units) below; low and high end bracket the measured number.
By their numbers in this assay, from the lowest: compound 2; then compound 3; then compound 4. At a limit, above all of these: compound 1.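

In this assay, the exchange of the sulfur-containing ring for the nitrogen-containing one, with the point of attachment kept, gives a 3.3-fold higher number from compound 3 to compound 4 (0.51 log units; beyond the scatter), so the identity of the hetero atom alone moves the number beyond the scatter at this position, a step classed as modest, as is a 3.6-fold higher number from compound 2 to compound 3 (0.56 log units; beyond the scatter). Among the three five-membered groups the numbers now rise in the order thiophen-2-yl, thiophen-3-yl, 1H-pyrrol-3-yl, and the two ends of that order are set apart by a 12-fold higher number from compound 2 to compound 4 (1.07 log units; beyond the scatter), a large step that changes both the hetero atom and the point of attachment. Even this least toxic of the three five-membered groups stays well short of phenyl, with an at least 24-fold lower number from compound 1 to compound 4 (1.39 log units; beyond the scatter), and that step starts from a limit: the limit of > 50000 nM in this assay, at which 1 of the 4 values shown sits.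

Going by these compounds, it remains open where furan-3-yl, with oxygen as the hetero atom, or 1H-pyrrol-2-yl would fall in this order, and whether a methyl group on the pyrrole nitrogen would shift the number of compound 4. Also open, on these data alone, is whether a six-membered ring with a ring nitrogen, such as pyridin-3-yl, would stay with phenyl or join the five-membered groups.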